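A few compounds are considered here, and "the series" means these few. Any claim that something is new, unique, unknown or untested is made for them only; others in the source may bear on it.

Measured in a functional assay on K562 cells (Homo sapiens) for inhibition, read by fluorescence, with a stated time of 72 h; on this read-out higher numbers stand for weaker inhibition of growth and lower numbers for stronger inhibition of growth:
- compound 1 `COc1ccc(Nc2nc(N[C@H]3CC[C@H](N)CC3)nc3c2ncn3CCC(C)C)c(OC)c1`: 5500 nM
- compound 2 `N[C@H]1CC[C@H](Nc2nc(Nc3ccc(Cl)cc3)c3ncn(C4CCCCC4)c3n2)CC1`: 1700 nM
- compound 3 `CCCCCCn1cnc2c(Nc3cccc(Cl)c3)nc(N[C@H]3CC[C@H](N)CC3)nc21`: 2300 nM

Compound 1 has the highest number of the three, which makes it the weakest growth inhibitor here. Compound 4 `CC(C)CCn1cnc2c(Nc3ccccc3)nc(N[C@H]3CC[C@H](N)CC3)nc21` has not yet been measured and differs from compound 1 in one place: phenyl in place of 2,4-dimethoxyphenyl on a nitrogen on an aromatic ring.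

Among the compounds with values here, no measured pair shows this change alone, so any forecast is loose. Neither of the other two compounds carries the 2,4-dimethoxyphenyl group, and both give lower numbers in this assay, with compound 2 at 1700 nM and compound 3 at 2300 nM. However, they also differ from compound 1 elsewhere, so they offer only a weak hint. A small move toward stronger inhibition is therefore expected, probably within the scatter. The expected change is a 1.8-fold lower number from compound 1 to compound 4 (0.26 log units; within the scatter). For compound 4 the estimated value is 3000 nM, with an expected range from 1200 nM to 8000 nM.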

Compound 4, concentration for 50% growth inhibition: 3500 nM
Compound 4: middle estimate off by 1.2-fold (0.07 log units), on the low side; low and high end bracket the measured number.
By their numbers in this assay, from the lowest: compounds 2, 3, 4 and 1 (each within the scatter of the next, the first and the last beyond it).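

In this assay, swapping 2,4-dimethoxyphenyl for phenyl on the nitrogen gives a 1.6-fold lower number from compound 1 to compound 4 (0.20 log units; within the scatter), a step within the scatter. Within the data shown here, this is the first pair that isolates this change, and it shows that growth inhibition cannot be told apart with and without the two methoxy groups, so the bare phenyl is tolerated at this position. Nothing measured here offers an explanation for this result.

Still open, from the compounds shown here alone, is whether either methoxy group alone would matter, as this pair removes both at once. Also open is what a chloro group, a nitrile or a carboxylic acid on the phenyl of compound 4 would do: compounds 2 and 3 carry chlorine but also differ from compound 4 in other places, and the other two groups appear in none of these compounds.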